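The source may hold more compounds than are shown below. What is called first, only, known or untested is meant among the compounds shown, and "the series" means these compounds.

Compound 1, `C=CC1=C(C(=O)NCCC)C(c2ccc(Cl)c(Cl)c2)OC1`: in a functional assay on HeLa cells (Homo sapiens) for cytotoxicity, read by MTT assay, with a stated time of 24 h (a higher number here means a weaker inhibitor, a lower number a stronger inhibitor), compound 1 gives > 100000 nM, which is a limit of the assay and not a number.
Compound 2, `C=CC1=C(C(=O)Nc2ccc(OCC)cc2)C(c2ccc(F)cc2)OC1`: compound 2 gives > 100000 nM, again a limit rather than a number.
Compound 3, `C=CC1=C(C(=O)NCc2ccc(C)cc2)C(c2ccc(OC)c(OC)c2)OC1`: compound 3 gives > 100000 nM, also a limit.

Compound 1 therefore stands nowhere in particular among the numbers shown: all three measured compounds sit at the limit of > 100000 nM in this assay, at which 3 of the 3 values shown sit, so no ordering among them can be read, and no step between measured compounds is available to judge what any change on the amide side of the shared core does.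

The unmeasured compound 4, `C=CC1=C(C(=O)NCCCCC)C(c2ccc(Cl)c(Cl)c2)OC1`, is reached from compound 1 by a single change: ethyl in place of hydrogen on a saturated chain carbon, three bonds along the chain from an amide-type nitrogen. Without any measured step to lean on, and with compound 1 and its two neighbours all resting at the limit, the expectation is for no movement beyond the scatter; the step of a number no higher from compound 1 to compound 4 (the limit leaves the size open) is expected to be essentially flat. Compound 4 is accordingly estimated at 100000 nM, with a range from 30000 nM to 300000 nM, and most likely this assay will once more report only a limit for compound 4.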

Compound 4, half-maximal inhibitory concentration: > 100000 nM
Compound 4: no number, only a limit; the forecaster's own chance of this, stated with the estimate: 80%; the middle value lies on the limit itself.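

In this assay compound 4 gives > 100000 nM, a limit of the assay and not a number. For the compounds shown here, compound 1 also rests at a limit, so no step between compound 1 and compound 4 can be read: the limit of > 100000 nM in this assay, at which 4 of the 4 values shown sit. The compounds shown leave open whether any compound on the shared core gives a measurable value in this assay.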